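Swapping a bromobenzyl for a straight chain in a chalcone amide

This account rests on a few compounds, and the source may have more. Where it says the series, first, only, none or still open, it means among the compounds named here.

Of the compounds shown here, two have been measured in a functional assay on HeLa cells (Homo sapiens) for inhibition, read by MTT assay; on this read-out higher numbers stand for weaker inhibition and lower numbers for stronger inhibition. Compound 1 `O=C(CBr)Nc1ccc(C(=O)/C=C/c2cn(Cc3ccc(Br)cc3)nn2)cc1` gives 7950 nM, the lower of the two numbers. Compound 2 `CCCCCCCCCCn1cc(/C=C/C(=O)c2ccc(NC(=O)CN3CCN(c4ccccc4)CC3)cc2)nn1` gives 59100 nM in this assay, a difference from compound 1 that lies beyond the usual scatter; compound 2 differs from compound 1 in more than one place, so no single change can be read from that pair.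

Compound 3 `CCCCCCCCn1cc(/C=C/C(=O)c2ccc(NC(=O)CBr)cc2)nn1` has not yet been measured. It keeps the bromoacetamide and the shared core of compound 1 and differs from it in one place: heptyl in place of 4-bromophenyl on a saturated chain carbon bound to an aromatic nitrogen. Compound 2 also carries a long saturated chain on the same aromatic nitrogen, but its amide end is different, so the data give no isolated reading of this chain swap.

Within the data shown here, with no measured step of this kind to lean on, the expected step of a 1.3-fold higher number from compound 1 to compound 3 (0.10 log units; within the scatter) is a small one, if any, and could fall in either direction within the scatter. Compound 3 is therefore estimated at 10000 nM in this assay, with a range from 3000 nM to 35000 nM.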

Compound 3, half-maximal inhibitory concentration: 8420 nM
The estimate for compound 3 lay 1.2-fold (0.07 log units) above the measured number; the range from low to high includes it.
By their numbers in this assay, from the lowest: compounds 1 and 3 (each within the scatter of the next); then compound 2.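

In this assay, among these compounds, this swap can now be read on its own for the first time: the step is a 1.1-fold higher number from compound 1 to compound 3 (0.02 log units; within the scatter) and stays within the usual scatter. A group built on a six-membered aromatic ring of carbon with a bromine, and heptyl with no ring at all, therefore give numbers that cannot be told apart when placed on a saturated chain carbon bound to an aromatic nitrogen, with the bromoacetamide kept in both compounds. Nothing measured here explains this outcome.

This single pair cannot show whether the swap would be just as silent with a different amide end, such as the phenylpiperazine-bearing one in compound 2, where the chain has never been changed on its own. It also leaves open whether a chain ending in an amine or a carboxylic acid, or a much longer one such as dodecyl, would still fit this picture.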